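Isopropyl added to the saturated core of compound 1

The source may report more compounds than this note shows. Statements on the series, on what has been measured and on what is new or still open speak of the compounds shown alone.

Compound 1 `Cc1ccc(O)c(C(=O)NCCCN2CCC[C@@H]3CCCC[C@@H]32)c1` is known in a functional assay on MDBK cells (Bos taurus) for cytotoxicity (on this read-out higher numbers stand for lower toxicity in this test and lower numbers for higher toxicity in this test), only as a limit: compound 1 gives > 100 ug/mL, a limit of the assay and not a number. Compound 2 `O=C(NCCCN1CCC[C@@H]2CCCC[C@@H]21)c1cc(Cl)ccc1O` gives 43 ug/mL in this assay. The pair moves an at least 2.3-fold lower number from compound 1 to compound 2 (0.36 log units; beyond the scatter), but that change sits on the aromatic ring. Among the compounds with values here, compound 3 `Cc1ccc(O)c(C(=O)NCCCN2C(C(C)C)CC[C@@H]3CCCC[C@@H]32)c1` differs from compound 1 by isopropyl in place of hydrogen on a saturated ring carbon; no measured step covers this change, and compound 1 stands at the limit of > 100 ug/mL in this assay, at which 1 of the 2 values shown sits. The step of an at least 1.4-fold lower number from compound 1 to compound 3 (0.15 log units; that floor lies within the scatter) expected here is therefore small. Compound 3 is expected near 70 ug/mL, between 25 ug/mL and 150 ug/mL.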

Compound 3, half-maximal cytotoxic concentration: 80 ug/mL
Compound 3: the middle estimate sits 1.1-fold (0.06 log units) below what was measured, and the stated range covers the measured number.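

Isopropyl in place of hydrogen on this saturated ring carbon, next to the ring nitrogen, gives an at least 1.2-fold lower number from compound 1 to compound 3 (0.09 log units; that floor lies within the scatter) in this assay, the only step shown on the saturated core rather than the aromatic ring. Compound 1 gives > 100 ug/mL, a limit of the assay and not a number. The floor of this step can be read, but its true size cannot: the limit of > 100 ug/mL in this assay, at which 1 of the 3 values shown sits.

From the compounds shown here alone, whether a smaller methyl, a longer chain or an amine on this ring carbon would move the number remains open. So does the outcome of isopropyl on the other saturated ring carbons.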